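Swapping 4-fluorophenyl for 3-chlorophenyl on compound 3

The compounds below may be only part of what the source reports. "The series", "measured", "known", "first", "only" and "open" are said of these compounds alone.

In a physicochemical assay for solubility, read by HPLC, in phosphate buffer, measured as kinetic solubility, at pH 7.4 (a higher number here means a more soluble compound, a lower number a less soluble compound), compound 1 (`CCC(=O)c1cc(-c2cccc(Cl)c2)n(-c2ccc(S(N)(=O)=O)cc2)c1C`) gives 12600 nM and compound 2 (`CCOC(=O)c1cc(-c2ccc(F)cc2)n(-c2ccc(S(N)(=O)=O)cc2)c1C`) gives 12600 nM. Compound 3 (`Cc1c(C(=O)O)cc(-c2ccc(F)cc2)n1-c1ccc(S(N)(=O)=O)cc1`) gives 50000 nM, the highest of the three numbers. Compound 4 (`Cc1c(C(=O)O)cc(-c2cccc(Cl)c2)n1-c1ccc(S(N)(=O)=O)cc1`) has 3-chlorophenyl in place of 4-fluorophenyl on an aromatic carbon, and the counted difference is 3-chlorophenyl in place of 4-fluorophenyl on an aromatic carbon.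

Among the compounds with values here, the only measured step between compounds that differ in one place, a 4.0-fold higher number from compound 2 to compound 3 (0.60 log units; beyond the scatter), is modest and lies at the carboxy group, so it does not test this swap. The nearest evidence is indirect. Compound 1, with 3-chlorophenyl, shows 12600 nM, and compound 2, with 4-fluorophenyl, shows the same number at 12600 nM, although the two also differ elsewhere. A change beyond the scatter in this assay is therefore not expected, though a slight drop is allowed for. The expected change is a 1.3-fold lower number from compound 3 to compound 4 (0.10 log units; within the scatter). The estimate for compound 4 is 40000 nM, with an expected range of 16000 nM to 63000 nM.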

Compound 4, solubility: 100000 nM
Compound 4: the middle estimate sits 2.5-fold (0.40 log units) below what was measured; the measured number lies above the stated range.
By their numbers in this assay, from the lowest: compounds 1 and 2 (each within the scatter of the next); then compounds 3 and 4 (each within the scatter of the next).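

In this assay, within the data shown here, the exchange of 4-fluorophenyl for 3-chlorophenyl gives a 2.0-fold higher number from compound 3 to compound 4 (0.30 log units; within the scatter) as the first direct reading at this aromatic carbon next to the ring nitrogen, and it does not separate the two groups beyond the usual scatter. With 3-chlorophenyl present in both compounds, hydroxy in place of ethyl on a carbonyl carbon gives a 7.9-fold higher number from compound 1 to compound 4 (0.90 log units; beyond the scatter) as a modest step, so a change at the carbonyl group now also reads beyond the scatter with this aryl group. No measurement here gives a reason for either step.

The compounds shown leave open whether the two aryl groups would also read alike with an ethyl ester or a propanoyl group in place of the carboxy group. They also leave open how a pyridine ring or an aminophenyl group would read on this same aromatic carbon.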